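This account rests on a few compounds, and the source may have more. Where it says the series, first, only, none or still open, it means among the compounds named here.

Three ureas built on the shared core of compound 1, `CC(C)c1cccc(C(C)C)c1NC(=O)NCC1(c2ccc(Cl)cc2)CCCC1`, differ only in the aromatic group attached to a saturated ring carbon. In an assay on microsomes for inhibition of acyl-CoA:cholesterol acyltransferase (Oryctolagus cuniculus) (on this read-out lower numbers stand for stronger inhibition and higher numbers for weaker inhibition), compound 1 gives 32 nM, compound 2, `CC(C)c1cccc(C(C)C)c1NC(=O)NCC1(c2ccccc2C(F)(F)F)CCCC1`, gives 18 nM, and compound 3, `CC(C)c1cccc(C(C)C)c1NC(=O)NCC1(c2cccc([N+](=O)[O-])c2)CCCC1`, gives 51 nM, the highest of the three numbers. Its gap to compound 1 is small: a 1.6-fold higher number from compound 1 to compound 3 (0.20 log units; within the scatter). Its gap to compound 2 is larger: a 2.8-fold higher number from compound 2 to compound 3 (0.45 log units; beyond the scatter).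

Compound 4, `CC(C)c1cccc(C(C)C)c1NC(=O)NCC1(c2ccc(C(=O)O)cc2)CCCC1`, is the next member, with the change (4-carboxyphenyl in place of 3-nitrophenyl on a saturated ring carbon). The measured steps all exchange one substituted phenyl for another, as this change does, and none of them moved the number by more than a modest amount. Going by the values given here, the entering group brings a hydrogen-bond donor that none of the measured compounds carries, so the comparison is looser than the ones already in hand. A small to modest step toward a higher number is expected, a 1.6-fold higher number from compound 3 to compound 4 (0.20 log units; within the scatter), and compound 4 is therefore estimated at 80 nM in this assay, with a likely range from 25 nM to 300 nM.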

Compound 4, half-maximal inhibitory concentration: 3100 nM
The estimate for compound 4 lay 39-fold (1.59 log units) below the measured number; the whole stated range lies below it.
By their numbers in this assay, from the lowest: compounds 2, 1 and 3 (each within the scatter of the next, the first and the last beyond it); then compound 4.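

Until now, exchanging one substituted phenyl for another on this saturated ring carbon had moved the number by a modest amount at most, but 4-carboxyphenyl shows that this position does not accept every such group (a 61-fold higher number from compound 3 to compound 4 (1.78 log units; beyond the scatter); a 170-fold higher number from compound 2 to compound 4 (2.24 log units; beyond the scatter)). The large rise also appears in the comparison that changes only the substituent, carboxy in place of chloro on an aromatic carbon (a 97-fold higher number from compound 1 to compound 4 (1.99 log units; beyond the scatter)). Nothing shown here offers a measured explanation for this jump.

As far as these compounds go, whether the loss belongs to the carboxylic acid itself or to its place on the phenyl remains open, and a methyl ester, a primary amide or a 3-carboxyphenyl group could help separate these possibilities. From the compounds shown here alone, it is also open whether a phenyl bearing a hydroxy group or an amine, each with a hydrogen-bond donor, would show a similar rise.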